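Ethyl in place of 3-chlorobenzyl on the shared core

The source may report more compounds than this note shows. Statements on the series, on what has been measured and on what is new or still open speak of the compounds shown alone.

Compound 1, `CCOC(=O)c1ccc(-c2nn(Cc3cccc(Cl)c3)c3ccccc23)cc1`, in a functional assay on cells (Platelet, Homo sapiens) for inhibition (on this read-out lower numbers stand for stronger inhibition and higher numbers for weaker inhibition), gives > 10000 nM, a limit of the assay rather than a number.
Compound 2, `CCOC(=O)c1ccc(-c2nn(Cc3ccc(Cl)cc3)c3ccccc23)cc1`, in this assay gives > 10000 nM, again a limit and not a number.
Compound 3, `CCOC(=O)c1ccc(-c2nn(Cc3cccc(OC)c3)c3ccccc23)cc1`, in this assay gives > 10000 nM, likewise only a limit.

Compound 1 thus stands at the limit of > 10000 nM in this assay, at which 3 of the 3 values shown sit, so its place among the three cannot be read. The steps between the measured compounds, a step that the two limits leave unreadable from compound 1 to compound 2, a step that the two limits leave unreadable from compound 1 to compound 3 and a step that the two limits leave unreadable from compound 2 to compound 3, give no readable size, since each ends at a limit.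

Compound 4, `CCOC(=O)c1ccc(-c2nn(CC)c3ccccc23)cc1`, differs from compound 1 by methyl in place of 3-chlorophenyl on a saturated chain carbon bound to an aromatic nitrogen. For the measured compounds named here, none of the measured steps touches this kind of change, and none of them is readable in any case, so no size or direction can be drawn from them for this assay. With all three measured values resting at the limit, the most that can be expected is that compound 4 also remains there. Compound 4 is therefore estimated at about 15000 nM, within the range from 5000 nM to 50000 nM. For compound 4 the expected step is a step that the limit leaves unreadable from compound 1 to compound 4, an estimate without support from any readable measurement.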

Compound 4, half-maximal inhibitory concentration: > 10000 nM
Compound 4: only a limit was reported (the forecaster's own chance of this, stated with the estimate: 85%); the middle value lies beyond the limit too.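

In this assay compound 4 gives > 10000 nM, which is a limit and not a number. The steps linking compound 4 to compound 1, compound 2 and compound 3 cannot be read: the limit of > 10000 nM in this assay, at which 4 of the 4 values shown sit.

The compounds shown leave open whether exchanging 3-chlorobenzyl for ethyl on the shared core changes inhibition at all.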